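Hydroxymethyl to 3-methyloxetan-3-yl: compound 3 to compound 4

This account rests on a few compounds, and the source may have more. Where it says the series, first, only, none or still open, it means among the compounds named here.

In an ADME assay on microsomes from liver (Rattus norvegicus) for metabolic stability, read by LC-MS, using NADPH, with a stated time of 30 min, tested at 1 uM (on this read-out higher numbers stand for fast clearance and lower numbers for slow clearance), compound 1 (`COc1cc2c(cn1)Oc1ccc(NC(=O)c3ccc(Cl)cn3)cc1[C@@]21COC(N)=N1`) reads < 14 mL.min-1.g-1 as a limit and not a number. Going by the values given here, compound 2 (`NC1=N[C@@]2(CO1)c1cc(-c3cncc(C#CC4CC4)c3)ccc1Oc1cnc(C3=CCOCC3)cc12`) gives 23 mL.min-1.g-1 and compound 3 (`NC1=N[C@@]2(CO1)c1cc(-c3cncc(C#CCO)c3)ccc1Oc1cnc(C3=CCOCC3)cc12`) gives 46 mL.min-1.g-1 as the only two actual numbers in the set, and these lie within the scatter of each other.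

Compound 4 (`CC1(C#Cc2cncc(-c3ccc4c(c3)[C@@]3(COC(N)=N3)c3cc(C5=CCOCC5)ncc3O4)c2)COC1`) carries 3-methyloxetan-3-yl in place of hydroxymethyl on a triple-bonded carbon and is still to be measured. Among the compounds with values here, the one measured step at that carbon, hydroxymethyl in place of cyclopropyl, is a 2.0-fold higher number from compound 2 to compound 3 (0.30 log units; within the scatter) and stays within the scatter. Within the data shown here, with only this step to go on, no move beyond the scatter is expected in this assay for the new group. The middle of the estimate is placed between the numbers of compound 2 and compound 3. The estimated step is a 1.4-fold lower number from compound 3 to compound 4 (0.16 log units; within the scatter) and it is not expected to pass the scatter. Compound 4 is expected at 32 mL.min-1.g-1 (estimated range 14 mL.min-1.g-1 to 70 mL.min-1.g-1).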

Compound 4, intrinsic clearance in microsomes: 73 mL.min-1.g-1
The estimate for compound 4 lay 2.3-fold (0.36 log units) below the measured number; measured number above the stated range.
By their numbers in this assay, from the lowest: compounds 2, 3 and 4 (each within the scatter of the next, the first and the last beyond it). At a limit, below all of these: compound 1.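

At the triple-bonded carbon, 3-methyloxetan-3-yl in place of hydroxymethyl gives a 1.6-fold higher number from compound 3 to compound 4 (0.20 log units; within the scatter) in this assay, so this exchange alone does not separate the two groups. Going by these compounds alone, the position nevertheless proves able to shift this read-out: 3-methyloxetan-3-yl in place of cyclopropyl gives a 3.2-fold higher number from compound 2 to compound 4 (0.50 log units; beyond the scatter), the first step at this carbon to pass the scatter, although its size remains modest. No measurement shown here gives a cause for either step.

A single step beyond the scatter among cyclopropyl, hydroxymethyl and 3-methyloxetan-3-yl does not establish a trend at this carbon. Still open, on these data alone, is how oxetan-3-yl without the methyl, a dimethylaminomethyl group or a carboxylic acid at the same carbon would read against compound 2 and compound 4.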